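Moving the fluorine on the aryl hydrazone of compound 2

The source may report more compounds than this note shows. Statements on the series, on what has been measured and on what is new or still open speak of the compounds shown alone.

Of the compounds shown here, three share a trimethoxyphenyl unit and have been measured in a functional assay on PC-3 cells (Homo sapiens) for antiproliferative activity, read by MTT assay, tested at 5 uM; on this read-out higher numbers stand for a stronger effect at the one concentration tested and lower numbers for a weaker effect. Compound 1 `COc1cc(C2=NN(C(C)=O)C(c3c(Cl)cccc3Cl)O2)cc(OC)c1OC` gives -2.2%, compound 2 `COc1cc(C(=O)N/N=C/c2cccc(F)c2)cc(OC)c1OC` gives 64.1%, and compound 3 `COc1cc(C(=O)N/N=C/c2cccc(C(F)(F)F)c2)cc(OC)c1OC` gives 79.8%. Compound 2 thus stands second of the three numbers: compound 3 lies a number 15.7 percentage points higher from compound 2 to compound 3 (beyond the scatter), whereas compound 1 lies far lower, beyond the scatter. Within the data shown here, the only step recorded among them, trifluoromethyl in place of fluoro on an aromatic carbon, is that from compound 2 to compound 3, and it is modest.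

Compound 4 `COc1cc(C(=O)N/N=C/c2ccccc2F)cc(OC)c1OC` differs from compound 2 as follows: 2-fluorophenyl in place of 3-fluorophenyl on a carbon with a double bond to nitrogen. Among the measured compounds shown here, no measured step shows what moving the fluorine from a 3-fluorophenyl to a 2-fluorophenyl does in this assay, so the step from compound 2 to compound 3 bears on it only loosely, as a sign that small changes on this ring shift the read-out modestly. The account therefore expects a step in this assay of about a number 6.1 percentage points lower from compound 2 to compound 4 (within the scatter), that is, no shift beyond the scatter, with a slight lean downward. Compound 4 is estimated at 58%, in the range 35% to 78%.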

Compound 4, a percentage reported as inhibition, at one concentration (the size of the read-out at that concentration, not a potency): 81.8%
Compound 4: middle estimate off by 23.8 percentage points, on the low side; measured number above the stated range.
By their numbers in this assay, from the lowest: compound 1; then compound 2; then compounds 3 and 4 (each within the scatter of the next).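

In this assay, moving the fluorine alone, with the same atoms joined differently, gives a number 17.7 percentage points higher from compound 2 to compound 4 (beyond the scatter) and so lifts the read-out beyond the scatter. Among these compounds, until now, the only step on this ring was a change of group, a number 15.7 percentage points higher from compound 2 to compound 3 (beyond the scatter); this one shows that the place of a single fluorine on the ring also counts at the carbon with a double bond to nitrogen. Nothing at hand bears on why the number rises.

The compounds shown leave open whether the gain belongs to fluorine itself or would also appear with a 2-chlorophenyl or a 2-methoxyphenyl group in its place. They also leave open how a 4-fluorophenyl group would read, and whether trifluoromethyl would respond to a move as fluorine does in a 2-(trifluoromethyl)phenyl group.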